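Oxane-substituted chain in place of the aminopropenyl arm

This account rests on a few compounds, and the source may have more. Where it says the series, first, only, none or still open, it means among the compounds named here.

Measured compounds:
- Compound 1 `NCCCCN(C[C@H]1Cc2cccnc2CN1)[C@H]1CCCc2cccnc21`: 6 nm/s
- Compound 2 `NCCCCN(C[C@H]1Cc2nccnc2CN1)[C@H]1CCCc2cccnc21`: 2 nm/s
- Compound 3 `NC/C=C/CN(C[C@H]1Cc2ncccc2CN1)[C@H]1CCCc2cccnc21`: 15 nm/s

All three were run in an ADME assay for permeability, using PAMPA, with a stated time of 4 h, at pH 7.4; a lower number here means that the compound crosses the layer more slowly, a higher number that the compound crosses the layer faster. Among the three numbers, compound 3 stands highest: compound 1 lies nearest, with a lower number beyond the usual scatter, and compound 2 lies furthest, also below it beyond the scatter. Compound 4 `c1cnc2c(c1)CN[C@@H](CN(CCCCNC1CCOCC1)[C@H]1CCCc3cccnc31)C2` has not yet been measured. It differs from compound 3 in one place: 3-((oxan-4-yl)amino)propyl in place of 3-aminoprop-1-en-1-yl on a saturated chain carbon bound to an amine nitrogen. Among the compounds with values here, no measured pair shows this kind of change, so no step can be read off directly; the two values of compound 1 and compound 2 only show that the shared core itself permits numbers below that of compound 3. Given the single starting point of compound 3 at 15 nm/s, the step in this assay is expected to be small, most likely upward or none beyond the scatter, as expressed by a 1.3-fold higher number from compound 3 to compound 4 (0.12 log units; within the scatter). For compound 4 the estimated value in this assay is 20 nm/s, with a range from 8 nm/s to 50 nm/s.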

Compound 4, apparent permeability: 8 nm/s
Compound 4: the middle estimate sits 2.5-fold (0.40 log units) above what was measured; the measured number falls inside the stated range.
By their numbers in this assay, from the lowest: compound 2; then compounds 1, 4 and 3 (each within the scatter of the next, the first and the last beyond it).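

In this assay, within the data shown here, the change on a saturated chain carbon bound to an amine nitrogen, 3-((oxan-4-yl)amino)propyl in place of 3-aminoprop-1-en-1-yl, gives a 1.9-fold lower number from compound 3 to compound 4 (0.27 log units; within the scatter) and is the first step that can be read at this place. The arm that enters has 10 heavy atoms and one six-membered non-aromatic ring, the arm that leaves has 4 heavy atoms and no ring, yet the two numbers cannot be told apart here. No measurement at hand offers a reason for the size of this step.

As far as these compounds go, the ring and the loss of the double bond arrive together in this single step, so what each contributes alone stays open. Also open, from the compounds shown here alone, is how a cyclohexyl or a piperidin-4-yl group in place of the oxan-4-yl group would read in this assay on this arm.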